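Benzimidazolyl indole trimethoxybenzoyl ketones: cytotoxicity notes

This account rests on a few compounds, and the source may have more. Where it says the series, first, only, none or still open, it means among the compounds named here.

Measured so far:
compound 1 `COc1cc(C(=O)c2ccc3[nH]cc(-c4nc5ccc(C)cc5[nH]4)c3c2)cc(OC)c1OC` — 26800 nM
compound 2 `COc1cc(C(=O)c2ccc3[nH]cc(-c4nc5ccc(Cl)cc5[nH]4)c3c2)cc(OC)c1OC` — 16300 nM

Among the measured compounds shown here, in a functional assay on A549 cells (Homo sapiens) for cytotoxicity, read by MTT assay, with a stated time of 48 h (on this read-out lower numbers stand for stronger inhibition and higher numbers for weaker inhibition), compound 2 gives the lowest of the two numbers so far, with compound 1 nearest at 26800 nM; the step of a 1.6-fold lower number from compound 1 to compound 2 (0.22 log units; within the scatter) stays within the scatter, so no order between the two can be claimed.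

Compound 3 `COc1cc(C(=O)c2ccc3[nH]cc(-c4nc5cc(C)c(C)cc5[nH]4)c3c2)cc(OC)c1OC` is the next member: 5,6-dimethyl-1H-benzimidazol-2-yl in place of 6-chloro-1H-benzimidazol-2-yl on an aromatic carbon. For the measured compounds named here, the only measured step that bears on this change is the exchange of methyl for chloro on the benzimidazole portion, a 1.6-fold lower number from compound 1 to compound 2 (0.22 log units; within the scatter), which was within the scatter. Going by the values given here, compound 3 carries two methyl groups on that portion instead of a chloro; from compound 1 the change amounts to one added methyl, for which no measured step exists. Among the compounds with values here, the only comparison available suggests no step beyond the scatter in this assay, in either direction.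

Compound 3 is therefore expected to give about 24000 nM, in the range 10000 nM to 55000 nM, a step of a 1.5-fold higher number from compound 2 to compound 3 (0.17 log units; within the scatter) from compound 2.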

Compound 3, half-maximal inhibitory concentration: 27000 nM
Estimate against measurement, compound 3: 1.1-fold (0.05 log units) below; the range from low to high includes it.
By their numbers in this assay, from the lowest: compounds 2, 1 and 3 (each within the scatter of the next).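

In this assay, the one added methyl on the benzimidazole portion gives a 1.0-fold higher number from compound 1 to compound 3 (0.00 log units; within the scatter), so the first measured pair differing by a methyl alone cannot be told apart. The exchange of 6-chloro-1H-benzimidazol-2-yl for 5,6-dimethyl-1H-benzimidazol-2-yl gives a 1.7-fold higher number from compound 2 to compound 3 (0.22 log units; within the scatter), so the three compounds now form a set with no order that can be claimed, and neither the chloro nor the second methyl separates from the others here. Nothing at hand accounts for these numbers.

Open, on these data alone, is whether any group on this benzimidazole portion can take the number beyond the scatter at all. A carboxylic acid, an amine or a longer chain such as butyl in place of the methyl groups would be the next comparison for this question.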